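The compounds below may be only part of what the source reports. "The series", "measured", "known", "first", "only" and "open" are said of these compounds alone.

Among the compounds with values here, in an ADME assay on HEK-293T cells (Homo sapiens) for cytotoxicity, read by MTT assay, with a stated time of 48 h (a higher number here means that more compound is tolerated, a lower number that less compound is tolerated), the series so far yields only limits. Compound 2 (`Cn1cc(C2CC(c3ccc(Cl)cc3)=NN2C(=O)c2cccnc2)c2cc(Br)ccc21`) reads > 300000 nM, which is a limit and not a number. Compound 3 (`COc1cc(C2=NN(C(=O)c3cccnc3)C(c3cn(C)c4ccc(Br)cc34)C2)cc(OC)c1OC`) differs from it by 3,4,5-trimethoxyphenyl in place of 4-chlorophenyl on a carbon with a double bond to nitrogen, with 3,4,5-trimethoxyphenyl in place of 4-chlorophenyl on a carbon with a double bond to nitrogen. Compound 1 (`COc1cc(C2=NN(C(=O)c3ccc(C)nc3)C(c3cn(C)c4ccccc34)C2)cc(OC)c1OC`) already carries the 3,4,5-trimethoxyphenyl group, and its > 300000 nM is also a limit. No measured step sizes this change, so the expected a number no higher from compound 2 to compound 3 (the limit leaves the size open) stays within the usual scatter, in no particular direction. Compound 3 is expected at 300000 nM, with an estimated range of 150000 nM to 600000 nM.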

Compound 3, half-maximal cytotoxic concentration: 131000 nM
Estimate against measurement, compound 3: 2.3-fold (0.36 log units) above, and the stated range ends above it.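

In this assay, within the data shown here, compound 3 gives the first value that is a number and not a limit, 131000 nM. This shows that the group on the carbon with a double bond to nitrogen can move the read-out: 3,4,5-trimethoxyphenyl in place of 4-chlorophenyl gives an at least 2.2-fold lower number from compound 2 to compound 3 (0.35 log units; beyond the scatter). The full size of the step stays open because compound 2 stands at a limit: the limit of > 300000 nM in this assay, at which 2 of the 3 values shown sit.

Going by these compounds, it remains open whether all three methoxy groups are needed for this step. On these data alone, how a 4-aminophenyl or 4-carboxyphenyl group would read at the same position is also open.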